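The source may hold more compounds than are shown below. What is called first, only, known or untested is meant among the compounds shown, and "the series" means these compounds.

Measured compounds:
compound 1, `Cn1c(-c2ccccc2)nnc1[S+](C)[O-]`, > 100 mg/kg (a limit of the test)
compound 2, `Cn1c(-c2ccccc2F)nnc1[S+](C)[O-]`, 57.9 mg/kg
compound 3, `Cn1nc(-c2ccccc2)nc1S(C)(=O)=O`, > 200 mg/kg (a limit of the test)

All three were run in a functional assay on the whole organism for antagonist activity, with Mus musculus as the target; on this read-out lower numbers stand for an effect already at smaller amounts and higher numbers for an effect only at larger amounts of compound. For compound 1 the read-out is only a limit, > 100 mg/kg. Compound 2 gives 57.9 mg/kg. The step between them is an at least 1.7-fold lower number from compound 1 to compound 2 (0.23 log units; that floor lies within the scatter), made by fluoro in place of hydrogen on an aromatic carbon. For compound 3 the read-out is again only a limit, > 200 mg/kg. How the core of compound 1 and the core of compound 3 differ is not broken down here. Compound 4, `Cn1nc(-c2cccc(F)c2)nc1S(C)(=O)=O`, is still unmeasured; it differs from compound 3 by fluoro in place of hydrogen on an aromatic carbon. This is the same kind of change as from compound 1 to compound 2, but the place differs: there the entering fluoro is ortho to a group of 9 heavy atoms, here it is meta to a large group. Because compound 3 sits at the limit of > 200 mg/kg in this assay, at which 1 of the 3 values shown sits, only a floor for the step is known. The change is expected to give an at least 1.3-fold lower number from compound 3 to compound 4 (0.12 log units; that floor lies within the scatter), resting on an at least 1.7-fold lower number from compound 1 to compound 2 (0.23 log units; that floor lies within the scatter). Compound 4 is thus expected to give about 150 mg/kg, estimated between 50 mg/kg and 400 mg/kg.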

Compound 4, dose for half-maximal effect: > 100 mg/kg
Compound 4: a limit, no number; the forecaster's own chance of this, stated with the estimate: 50%; the middle value does not contradict the limit.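

Compound 3 and compound 4 both stand only as limits, so the size of the step between them cannot be read. The compounds shown leave open whether fluoro in place of hydrogen changes anything on this core.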